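Aryl change at the carbonyl, compound 2 to compound 3

This account rests on a few compounds, and the source may have more. Where it says the series, first, only, none or still open, it means among the compounds named here.

For the measured compounds named here, in a functional assay on MDA-MB-231 cells (Homo sapiens), read by microscopy and transwell migration, with a stated time of 24 h (a higher number here means a weaker inhibitor, a lower number a stronger inhibitor), compound 1 `COc1cc(-c2cs/c(=N\C(=O)c3ccccc3)n2C)cc(OC)c1OC` gives 1070 nM and compound 2 `COc1cc(-c2cs/c(=N\C(=O)c3ccc(Cl)cc3)n2C)cc(OC)c1OC` gives 758 nM, so compound 2 stands within the scatter of its only neighbour. Compound 3 `COc1cccc(C(=O)/N=c2\scc(-c3cc(OC)c(OC)c(OC)c3)n2C)c1` carries 3-methoxyphenyl in place of 4-chlorophenyl on a carbonyl carbon. Going by the values given here, the only measured step bearing on this change is a 1.4-fold lower number from compound 1 to compound 2 (0.15 log units; within the scatter), chloro in place of hydrogen on an aromatic carbon. With so little evidence, no change beyond the scatter is expected in this assay. The expected step is a 1.1-fold higher number from compound 2 to compound 3 (0.05 log units; within the scatter). For compound 3 the estimate is 850 nM, with an expected range of 300 nM to 2500 nM.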

Compound 3, half-maximal inhibitory concentration: > 50000 nM
Compound 3: only a limit was reported (the forecaster's own chance of this, stated with the estimate: 3%); at least 58-fold (1.76 log units) between middle value and limit.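

In this assay the aryl group on the carbonyl carbon proves far from indifferent: 3-methoxyphenyl in place of 4-chlorophenyl gives an at least 65-fold higher number from compound 2 to compound 3 (1.81 log units; beyond the scatter), and methoxy in place of hydrogen gives an at least 46-fold higher number from compound 1 to compound 3 (1.66 log units; beyond the scatter), whereas chloro in place of hydrogen stayed within the scatter. The series therefore holds one change at this position that costs heavily and one that does not. Compound 3 has only a limit of the assay, not a number, so both large steps are open-ended: the limit of > 50000 nM in this assay, at which 1 of the 3 values shown sits.

Still open, going by these compounds, is whether the loss follows the methoxy group itself or its place on the ring, which 4-methoxyphenyl or 3-chlorophenyl on the carbonyl carbon would tell.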